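The source may report more compounds than this note shows. Statements on the series, on what has been measured and on what is new or still open speak of the compounds shown alone.

Measured so far in an assay on nucleic acid for binding affinity to Salmon testes DNA (Salmonidae), tested at 10 uM; on this read-out higher numbers stand for stronger stabilisation of the target against heat and lower numbers for weaker stabilisation of the target:
compound 1 `CC(C)CCc1sc(NC(=O)c2cc(NC(=O)c3cc(NC(=N)c4cccc(F)c4)cn3C)cn2C)nc1C(=O)NCCCN(C)C` gives 4 degrees C
compound 2 `CC(C)CCc1sc(NC(=O)c2cc(NC(=O)c3cc(NC(=N)c4cccc(Cl)c4)cn3C)cn2C)nc1C(=O)NCCCN(C)C` gives 5 degrees C

Among the compounds with values here, compound 2 carries the higher of the two numbers, but the only measured step, a number 1.0 degrees C higher from compound 1 to compound 2 (within the scatter), lies within the scatter, so the two compounds cannot be separated on this read-out.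

The next compound, compound 3 `CC(C)CCc1sc(NC(=O)c2cc(NC(=O)c3cc(NC(=N)c4ccc(Cl)cc4)cn3C)cn2C)nc1C(=O)NCCCN(C)C`, keeps every atom of compound 2 and rearranges one group: 4-chlorophenyl in place of 3-chlorophenyl on a carbon with a double bond to nitrogen. Within the data shown here, no measured step bears directly on this change. Among the measured compounds shown here, the single step in hand, a number 1.0 degrees C higher from compound 1 to compound 2 (within the scatter), swaps one halogen for another at the same place on the ring and stays within the scatter; no measured pair moves a substituent from one position of the phenyl ring to another. With a halogen change at the same place leaving the melting-temperature shift unchanged within the scatter, the expectation for a positional move of the same chlorine is likewise a step of no size beyond the scatter, no change at the digits printed from compound 2 to compound 3 (within the scatter), in either direction.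

Compound 3 is therefore estimated at 5 degrees C, with a range from 3 degrees C to 7 degrees C.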

Compound 3, shift of the target's melting temperature: 4 degrees C
For compound 3 the middle estimate is 1.0 degrees C above the measured one, within the range that was stated.
By their numbers in this assay, from the lowest: compounds 1, 3 and 2 (each within the scatter of the next).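

In this assay, within the data shown here, taking 4-chlorophenyl in place of 3-chlorophenyl on the carbon with a double bond to nitrogen gives a number 1.0 degrees C lower from compound 2 to compound 3 (within the scatter) and is the first measured change in where the chlorine sits on this phenyl ring. Changing the halogen and its ring position together, with 4-chlorophenyl in place of 3-fluorophenyl, gives no change at the digits printed from compound 1 to compound 3 (within the scatter) and so also leaves the compounds unseparated, which means that none of the three changes among compounds 1, 2 and 3 can be read as a real difference on this read-out. No further measurement is available that bears on this result.

From the compounds shown here alone, all three compounds carry a single halogen on this phenyl ring, so it remains open whether an unsubstituted phenyl ring, a methoxy group, an amine or a carboxylic acid at this place would produce a step beyond the scatter. They also share everything else in the molecule, so the compounds shown do not tell how this read-out responds to a change elsewhere, such as a shorter chain in place of the dimethylaminopropyl group.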